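The compounds below may be only part of what the source reports. "The series", "measured", "known", "first", "only" and "open" are said of these compounds alone.

Working notes on the shared core of compound 1 `Cn1c(-c2ccc(NC(=O)CSc3nc4ccccc4o3)cc2)nc(-c2ccccc2)c1-c1ccccc1`, a series differing only in the aryl group on the sulfur of the thioacetamide chain. In a functional assay on MCF7 cells (Homo sapiens) for cytotoxicity, read by MTT assay, with a stated time of 24 h (a higher number here means a weaker inhibitor, a lower number a stronger inhibitor), compound 1 gives 11.2 ug/mL, compound 2 `Cn1c(-c2ccc(NC(=O)CSc3nc4ccccc4s3)cc2)nc(-c2ccccc2)c1-c1ccccc1` gives 15.8 ug/mL and compound 3 `Cc1nnc(SCC(=O)Nc2ccc(-c3nc(-c4ccccc4)c(-c4ccccc4)n3C)cc2)s1` gives 3.2 ug/mL. Compound 3 thus holds the lowest number of the three: the steps of a 3.5-fold lower number from compound 1 to compound 3 (0.54 log units; beyond the scatter) and a 4.9-fold lower number from compound 2 to compound 3 (0.69 log units; beyond the scatter) both lie beyond the scatter, while a 1.4-fold higher number from compound 1 to compound 2 (0.15 log units; within the scatter) does not. Compound 4 `Cn1ccnc1SCC(=O)Nc1ccc(-c2nc(-c3ccccc3)c(-c3ccccc3)n2C)cc1` carries the change (1-methyl-1H-imidazol-2-yl in place of 5-methyl-1,3,4-thiadiazol-2-yl on a sulfur). Going by the values given here, no measured step swaps one small five-membered ring for another; the two steps above concern only the loss of a fused ring. The number for compound 4 is therefore expected near that of compound 3, with a 1.6-fold higher number from compound 3 to compound 4 (0.19 log units; within the scatter), giving an estimate of 5 ug/mL (range 2 ug/mL to 12.6 ug/mL).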

Compound 4, half-maximal inhibitory concentration: 46.5 ug/mL
Estimate against measurement, compound 4: 9.3-fold (0.97 log units) below; measured number outside the range, above it.
By their numbers in this assay, from the lowest: compound 3; then compounds 1 and 2 (each within the scatter of the next); then compound 4.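

At this position on the sulfur, one five-membered aromatic ring cannot stand in for another in this assay: a 15-fold higher number from compound 3 to compound 4 (1.16 log units; beyond the scatter) is the largest step in the series. Losing the fused ring therefore does not by itself lower the number, as a 2.9-fold higher number from compound 2 to compound 4 (0.47 log units; beyond the scatter) and a 4.2-fold higher number from compound 1 to compound 4 (0.62 log units; beyond the scatter) both run the other way. Nothing measured here explains the gap between the two small rings. Still open, on these data alone, is whether the ring sulfur or the placement of the methyl carries the difference; a 5-methyl-1,3,4-oxadiazol-2-yl group on the sulfur would test the ring sulfur.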